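This account rests on a few compounds, and the source may have more. Where it says the series, first, only, none or still open, it means among the compounds named here.

Compound 1, `O=S(=O)(Nc1ccc2oc(-c3ccccc3)nc2c1)c1ccccc1F`, gives only a limit in an assay on cells for inhibition of HSP60/HSP10 (Homo sapiens), with a stated time of 60 min; a lower number here means a stronger inhibitor, a higher number a weaker inhibitor: > 100000 nM.
Compound 2, `O=S(=O)(Nc1ccc2oc(-c3ccccc3)nc2c1)c1cccc(Cl)c1`, likewise gives only a limit in this assay: > 100000 nM.
Compound 3, `O=S(=O)(Nc1ccc2oc(-c3ccccc3)nc2c1)c1cccc(O)c1`, gives a number in this assay: 76000 nM.

Compound 3 is the only one of the three with a measured number; the other two sit at the limit of > 100000 nM in this assay, at which 2 of the 3 values shown sit, so they cannot be ranked against each other. The step from compound 1 to compound 2 is a step that the two limits leave unreadable from compound 1 to compound 2. Among the measured compounds shown here, the step of an at least 1.3-fold lower number from compound 1 to compound 3 (0.11 log units; that floor lies within the scatter) and the step of an at least 1.3-fold lower number from compound 2 to compound 3 (0.11 log units; that floor lies within the scatter) show only that compound 3 reads lower than the limit, by a floor that lies within the scatter.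

Compound 4, `COc1ccc(Cl)cc1S(=O)(=O)Nc1ccc2oc(-c3ccccc3)nc2c1`, differs from compound 3 in one place: 5-chloro-2-methoxyphenyl in place of 3-hydroxyphenyl on a sulfonyl sulfur. For the measured compounds named here, the hydroxy group that marked the one measured number is gone, and a chloro and a methoxy arrive in its stead. Compound 1 and compound 2, which carry a fluoro or a chloro and no hydroxy, both stopped at the limit, so the step from compound 3 to compound 4 is expected to be a 1.7-fold higher number from compound 3 to compound 4 (0.23 log units; within the scatter), upward, with a fair chance that only a limit is reported. Compound 4 is estimated at 130000 nM, in a range from 40000 nM to 400000 nM.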

Compound 4, half-maximal inhibitory concentration: > 100000 nM
Compound 4 ended at the assay's limit (the forecaster's own chance of this, stated with the estimate: 65%); the middle value is on the limit's open side.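

In this assay, putting 5-chloro-2-methoxyphenyl in place of 3-hydroxyphenyl on the sulfonyl sulfur gives an at least 1.3-fold higher number from compound 3 to compound 4 (0.11 log units; that floor lies within the scatter), so this result does not establish a real loss, and the true size of the change stays hidden. Compound 4 is the first of these compounds with two groups on the ring attached to the sulfonyl sulfur, and it too gives only a limit, so among the compounds shown, only the one with the 3-hydroxyphenyl group has a measured number: the limit of > 100000 nM in this assay, at which 3 of the 4 values shown sit. The steps linking compound 4 to compound 1 and to compound 2 cannot be read, as all three values are limits.

From the compounds shown here alone, it remains open whether the hydroxy group itself accounts for the measured number of compound 3, since compound 4 differs from it by more than the loss of that group, and an amine or a carboxylic acid in place of the hydroxy would help to test this. Also open, going by these compounds, is how far compound 1, compound 2 and compound 4 lie past the limit, and whether they differ from one another at all.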